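Swapping Phenyl for Furan-2-yl in a Hydrazide Series

The source may report more compounds than this note shows. Statements on the series, on what has been measured and on what is new or still open speak of the compounds shown alone.

Compound 2 `NNC(=O)CCCN1C(=O)c2ccccc2NC1c1ccccc1` stands lowest of the two numbers recorded so far. In an assay on mitochondria for inhibition of Amine oxidase [flavin-containing] B (Bos taurus), read by fluorescence, with a stated time of 60 min (on this read-out lower numbers stand for stronger inhibition and higher numbers for weaker inhibition), compound 2 gives 370000 nM. Its nearest neighbour, compound 1 `COC(=O)CCCN1C(=O)c2ccccc2NC1c1ccco1`, in this assay gives 780000 nM, a higher number that lies beyond the usual scatter, so of the two, compound 1 shows the weaker inhibition. The two compounds differ in two places at once, so their values alone do not say which change matters.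

Compound 3 `NNC(=O)CCCN1C(=O)c2ccccc2NC1c1ccco1` has not yet been measured. It differs from compound 2 in one place: furan-2-yl in place of phenyl on a saturated ring carbon. Among the measured compounds shown here, no single-change step between measured compounds shows what this exchange does; compound 1 already carries the furan-2-yl group but also a different chain end, so it cannot settle the question. The expectation is therefore a modest step from compound 2 to compound 3, if any, leaning towards a somewhat higher number, a 1.3-fold higher number from compound 2 to compound 3 (0.11 log units; within the scatter). Compound 3 is estimated at 480000 nM in this assay, within a range from 200000 nM to 1100000 nM.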

Compound 3, half-maximal inhibitory concentration: 270000 nM
Estimate against measurement, compound 3: 1.8-fold (0.25 log units) above; low and high end bracket the measured number.
By their numbers in this assay, from the lowest: compounds 3 and 2 (each within the scatter of the next); then compound 1.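

In this assay, furan-2-yl in place of phenyl on the saturated ring carbon gives a 1.4-fold lower number from compound 2 to compound 3 (0.14 log units; within the scatter) and stays within the scatter, so this position takes either aromatic ring with no measurable change in inhibition, despite the change in ring size and the added ring oxygen. The chain end behaves differently: aminoamino in place of methoxy on the carbonyl carbon gives a 2.9-fold lower number from compound 1 to compound 3 (0.46 log units; beyond the scatter) and lies beyond the scatter, a modest gain in inhibition and the only one of the two single changes to exceed it. The difference first seen between the two earlier compounds can thus be tied to the chain end rather than to the ring group, although nothing available explains why either exchange has the outcome it does.

From the compounds shown here alone, it remains open whether the chain-end step would be the same with phenyl on the ring carbon instead of furan-2-yl. Also open, going by these compounds, is what a thiophen-2-yl ring at the saturated ring carbon, or a carboxylic acid or longer chain at the chain end, would do.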